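The compounds below may be only part of what the source reports. "The series", "measured", "known", "first", "only" and "open" are said of these compounds alone.

Measured compounds:
- Compound 1, `CC[C@@H](Nc1c(C#N)c(-c2ccc(-c3cccc(Cl)c3F)cc2)nc2cnccc12)C(N)=O`: 3.1
- Compound 2, `CCOc1ccccc1-c1ccc(-c2nc(NC(C)C(=O)O)c3ccncc3n2)cc1`: 2.1

In a physicochemical assay for lipophilicity, read by HPLC, at pH 7.5 (a higher number here means a more lipophilic compound, a lower number a more polar compound), compound 1 gives 3.1, the highest of the two numbers recorded. Going by the values given here, its nearest neighbour is compound 2, which in this assay gives 2.1, a gap beyond the scatter of repeated measurements; as no single structural step links these two compounds, only the two values themselves can be compared. The next compound, compound 3 `CC[C@@H](Nc1c(C#N)c(-c2ccc(-c3cccc(OC)c3)cc2)nc2cnccc12)C(N)=O`, has not yet been measured. It differs from compound 1 in one place: 3-methoxyphenyl in place of 3-chloro-2-fluorophenyl on an aromatic carbon. Among the compounds with values here, with no measured step of this kind available, the expectation rests on the nature of the groups exchanged, and the step from compound 1 to compound 3 is expected to be a number 0.80 log units lower from compound 1 to compound 3 (beyond the scatter), a fall beyond the scatter. Compound 3 is therefore estimated to give 2.3 in this assay, within a range of 1.9 to 2.7.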

Compound 3, distribution coefficient: 2.7
Compound 3: the middle estimate sits 0.40 log units below what was measured; low and high end bracket the measured number.
By their numbers in this assay, from the lowest: compound 2; then compound 3; then compound 1.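

In this assay, going by these compounds alone, the exchange of 3-chloro-2-fluorophenyl for 3-methoxyphenyl gives a number 0.40 log units lower from compound 1 to compound 3 (beyond the scatter) and provides the first measured step, showing that the read-out responds to a change at this aromatic carbon, para to a large group. The step is modest, and it arises although the entering and leaving groups have the same count of heavy atoms, with both halogens leaving as an oxygen and a hydrogen-bond acceptor enter. Nothing at hand accounts for the step.

The compounds shown leave open which part of the exchange carries the step, as the chlorine, the fluorine and the methoxy group all change together. Also open, on these data alone, is how an amine or a carboxylic acid on this ring would read in this assay within the same core.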